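Benzyl in place of vinyl on compound 3

This account rests on a few compounds, and the source may have more. Where it says the series, first, only, none or still open, it means among the compounds named here.

Measured in a functional assay on MCF7 cells (Homo sapiens) for inhibition, read by colorimetric assay and MTT assay, with a stated time of 72 h; on this read-out higher numbers stand for weaker inhibition and lower numbers for stronger inhibition
compound 1 `C#CCCCCOc1ncc(-c2ccccc2OC)n1C` gives 10000 nM
compound 2 `COc1ccccc1-c1cnc(OC)n1C` gives > 100000 nM as a limit of the assay, not a number
compound 3 `C=CCCOc1ncc(-c2ccccc2OC)n1C` gives 27000 nM

For the measured compounds named here, compound 3 at 27000 nM and compound 1 at 10000 nM are the only two actual numbers, and compound 3 holds the higher one. Compound 4 `COc1ccccc1-c1cnc(OCCCc2ccccc2)n1C` carries benzyl in place of vinyl on a saturated chain carbon, two bonds along the chain from an oxygen on an aromatic ring. Going by the values given here, two measured steps bear on this change. Allyl in place of hydrogen (an at least 3.7-fold lower number from compound 2 to compound 3 (0.56 log units; beyond the scatter)) and vinyl in place of but-3-yn-1-yl (a 2.7-fold higher number from compound 1 to compound 3 (0.43 log units; beyond the scatter)) both show the larger group with the lower number among these three compounds. Benzyl is larger than vinyl, so in this assay a modest move toward a lower number is expected (a 2.3-fold lower number from compound 3 to compound 4 (0.35 log units; beyond the scatter)). Compound 4 is therefore estimated at 12000 nM (3000 nM to 50000 nM).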

Compound 4, half-maximal inhibitory concentration: 3000 nM
For compound 4 the middle estimate is 4.0-fold (0.60 log units) above the measured one; the measured number falls inside the stated range.
By their numbers in this assay, from the lowest: compound 4; then compound 1; then compound 3. At a limit, above all of these: compound 2.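

Benzyl in place of vinyl gives a 9.0-fold lower number from compound 3 to compound 4 (0.95 log units; beyond the scatter), the first sign that this chain can end in an aromatic ring, and phenyl in place of propargyl gives a 3.3-fold lower number from compound 1 to compound 4 (0.52 log units; beyond the scatter), so this ring also outdoes the triple-bond ending. Phenethyl in place of hydrogen gives an at least 33-fold lower number from compound 2 to compound 4 (1.52 log units; beyond the scatter), the widest gap shown so far. That step rests on a limit and not a number: the limit of > 100000 nM in this assay, at which 1 of the 4 values shown sits.

Still open, from the compounds shown here alone, is whether the aromatic ring matters or only the chain's reach. A cyclohexyl ring or a plain hexyl chain at this place would separate the two.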